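The compounds below may be only part of what the source reports. "The series", "measured", "known", "first", "only" and "open" are said of these compounds alone.

Compound 3 `N#CC1=C(NC(=O)CCC(=O)O)N(c2ccc(S(N)(=O)=O)cc2)C2=C(C(=O)CCC2)C1c1ccc(Cl)cc1Cl` sits in the middle of the three measured compounds in a functional assay on Ehrlich cells (Mus musculus) for cytotoxicity, read by trypan blue exclusion, with a stated time of 2 h, tested at 100 ug/mL (a higher number here means a stronger effect of the compound at the concentration tested, a lower number a weaker effect), where compound 3 gives 60%. The unsubstituted parent, compound 1 `N#CC1=C(N)N(c2ccc(S(N)(=O)=O)cc2)C2=C(C(=O)CCC2)C1c1ccc(Cl)cc1Cl`, gives 95% in this assay, while compound 2 `C=CCNC(=S)NC1=C(C#N)C(c2ccc(Cl)cc2Cl)C2=C(CCCC2=O)N1c1ccc(S(N)(=O)=O)cc1` gives 40%. Both substituents on the amine nitrogen lowered the read-out: the step of a number 35 percentage points lower from compound 1 to compound 3 (beyond the scatter) and the larger step of a number 55 percentage points lower from compound 1 to compound 2 (beyond the scatter), whereas exchanging one substituent for the other gave a number 20 percentage points higher from compound 2 to compound 3 (beyond the scatter).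

Compound 4 `N#CC1=C(NS(=O)(=O)c2ccc([N+](=O)[O-])cc2)N(c2ccc(S(N)(=O)=O)cc2)C2=C(C(=O)CCC2)C1c1ccc(Cl)cc1Cl` carries a third kind of substituent at the same place: (4-nitrophenyl)sulfonyl in place of (2-carboxyethyl)carbonyl on an amine nitrogen.

The two steps from compound 1 bear on this, since each shows that placing a group on this amine nitrogen costs activity, and the exchange between compound 2 and compound 3 shows that which group it is matters only modestly. Compound 4 has a larger group here than either, with no hydrogen-bond donor, so a value between those of compound 2 and compound 3 is expected, somewhat below compound 3 because of a number 20 percentage points higher from compound 2 to compound 3 (beyond the scatter) being modest. The expected step is a number 15 percentage points lower from compound 3 to compound 4 (beyond the scatter). Compound 4 is therefore estimated at 45%, within a range from 15% to 80%.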

Compound 4, a percentage reported as activity, at one concentration (the size of the read-out at that concentration, not a potency): 90%
Compound 4: middle estimate off by 45 percentage points, on the low side; the measured number lies above the stated range.
By their numbers in this assay, from the lowest: compound 2; then compound 3; then compounds 4 and 1 (each within the scatter of the next).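

In this assay, the two earlier substituents had suggested that any group on this amine nitrogen lowers the read-out, but (4-nitrophenyl)sulfonyl breaks that reading: the step is a number 5 percentage points lower from compound 1 to compound 4 (within the scatter) and leaves compound 4 level with the unsubstituted parent. The choice of group also proves to matter more than the exchange of compound 2 for compound 3 indicated, with a number 30 percentage points higher from compound 3 to compound 4 (beyond the scatter) on replacing (2-carboxyethyl)carbonyl and a number 50 percentage points higher from compound 2 to compound 4 (beyond the scatter) on replacing the thiourea-bearing group of compound 2. This position therefore tolerates substitution with at least one large aromatic sulfonyl group, and the losses seen in compound 2 and compound 3 belong to those particular groups, not to substitution at this nitrogen as such.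

No measurement shown accounts for this difference among the groups. The sulfonyl link and the 4-nitrophenyl ring enter together, so the compounds shown leave open which of them carries the result, a question that a methylsulfonyl group, an unsubstituted phenylsulfonyl group or a 4-nitrobenzoyl group on this nitrogen would bear on, and a read-out at one concentration shows only the size of the effect of compound 4 and compound 1 at that concentration.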